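This account rests on a few compounds, and the source may have more. Where it says the series, first, only, none or still open, it means among the compounds named here.

The measured compounds:
compound 1 `NNc1nc2ccc(F)cc2s1` gives 13.8 ug/mL in an ADME assay on MT4 cells (Homo sapiens) for cytotoxicity, read by MTT assay, with a stated time of 5 days; a higher number here means that more compound is tolerated, a lower number that less compound is tolerated
compound 2 `NNc1nc2ccc(Br)cc2s1` gives 8.01 ug/mL in this assay
compound 3 `O=[N+]([O-])c1ccc(-c2nnc(-c3cccnc3)n2Nc2nc3ccc(F)cc3s2)cc1` gives >= 108 ug/mL in this assay

Compound 1 and compound 2 share a small core and differ in a single place: bromo in place of fluoro on an aromatic carbon. In this assay this change gave a 1.7-fold lower number from compound 1 to compound 2 (0.24 log units; within the scatter), so the two values cannot be told apart.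

Compound 3 carries a much larger core; the difference between the core of compound 1 and the core of compound 3 is not broken down here. The value of compound 3 in this assay is a limit of the assay, not a number, and it sits at the limit of >= 108 ug/mL in this assay, at which 1 of the 3 values shown sits.

Compound 4 `O=[N+]([O-])c1ccc(-c2nnc(-c3cccnc3)n2Nc2nc3ccc(Br)cc3s2)cc1` has not yet been measured in this assay. It differs from compound 3 by bromo in place of fluoro on an aromatic carbon, the same change as from compound 1 to compound 2, since the place lines of both changes agree word for word. Because the earlier step read a 1.7-fold lower number from compound 1 to compound 2 (0.24 log units; within the scatter), the step from compound 3 to compound 4 is expected to be small as well, estimated at an at least 1.0-fold lower number from compound 3 to compound 4 (0.03 log units; that floor lies within the scatter). For compound 4 the expected value in this assay is 100 ug/mL, with a range from 45 ug/mL to 220 ug/mL, and it is estimated that the assay will most likely again report only a limit for compound 4.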

Compound 4, half-maximal cytotoxic concentration: 13.2 ug/mL
For compound 4 the middle estimate is 7.6-fold (0.88 log units) above the measured one; measured number outside the range, below it.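

In this assay, bromo in place of fluoro on an aromatic carbon gave an at least 8.1-fold lower number from compound 3 to compound 4 (0.91 log units; beyond the scatter), and this step does not match the one seen on the smaller core: the same change on two cores in this assay, a 1.7-fold lower number (0.24 log units; within the scatter) from compound 1 to compound 2 and an at least 8.1-fold lower number (0.91 log units; beyond the scatter) from compound 3 to compound 4, at least 4.7-fold (0.67 log units) apart, beyond the scatter of two such steps The value of compound 3 is a limit of the assay and not a number, so the step from it has a floor but no known full size: the limit of >= 108 ug/mL in this assay, at which 1 of the 4 values shown sits. The two pairs therefore show that this change did not carry over with one size from the core of compound 1 to the core of compound 3, but they rest on only those two cores and do not show why the steps differ or how the change would read on any third core.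

Going by these compounds, it remains open whether chloro or methyl on the same aromatic carbon of the core of compound 3 would read like fluoro or like bromo, which would show whether bromo stands alone. On these data alone, it also remains open whether the gap between the two steps would persist if an amine or a carboxylic acid took the place of the nitro group on the larger core.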